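One Methoxy Fewer: From Compound 2 to Compound 3

The source may hold more compounds than are shown below. What is called first, only, known or untested is meant among the compounds shown, and "the series" means these compounds.

compound 1 `COc1ccc(-c2cc(/C=C/C(=O)c3ccc(N)cc3)[nH]n2)cc1`: 63600 nM
compound 2 `COc1cc(-c2cc(/C=C/C(=O)c3ccc(N)cc3)[nH]n2)cc(OC)c1OC`: 28900 nM

In a functional assay on SK-OV-3 cells (Homo sapiens) for inhibition, read by sulforhodamine B assay, with a stated time of 48 h (on this read-out higher numbers stand for lower toxicity in this test and lower numbers for higher toxicity in this test), compound 2 gives 28900 nM, the lower of the two numbers; compound 1 stands higher, beyond the scatter. Compound 3 `COc1ccc(-c2cc(/C=C/C(=O)c3ccc(N)cc3)[nH]n2)cc1OC` differs from compound 2 by hydrogen in place of methoxy on an aromatic carbon. Going by the values given here, no step between measured compounds isolates this change, so the direction is open; a small rise toward compound 1 is expected, as the step of a 1.4-fold higher number from compound 2 to compound 3 (0.14 log units; within the scatter) says, since compound 1 with one methoxy gives 63600 nM. Compound 3 is therefore estimated at 40000 nM, with a likely range from 15000 nM to 100000 nM.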

Compound 3, concentration lethal to 50% of the cells: 41300 nM
The estimate for compound 3 lay 1.0-fold (0.01 log units) below the measured number, within the range that was stated.
By their numbers in this assay, from the lowest: compounds 2, 3 and 1 (each within the scatter of the next, the first and the last beyond it).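

In this assay, hydrogen in place of methoxy on this aromatic carbon, ortho to a methoxy group, is a step within the scatter (a 1.4-fold higher number from compound 2 to compound 3 (0.16 log units; within the scatter)), and so is methoxy in place of hydrogen on an aromatic carbon (a 1.5-fold lower number from compound 1 to compound 3 (0.19 log units; within the scatter)). Compound 1 and compound 2 lie beyond the scatter of each other, yet compound 3 lies within the scatter of both, so neither single change separates its pair. No measurement here accounts for these steps.

Going by these compounds, it remains open whether a hydroxyl group or an amine in place of this methoxy would move the number beyond the scatter.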